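Boronate ester to carboxylic acid on the distal ring

The source may hold more compounds than are shown below. What is called first, only, known or untested is meant among the compounds shown, and "the series" means these compounds.

Working notes on a small set built around the core of compound 3 `O=C(NCc1ccccc1)[C@@H]1CCC(=O)N1Cc1ccccc1`. In an assay on HEK293 cells for inhibition of Ataxin-2 (Mus musculus), read by fluorescence and Amplex Red (on this read-out lower numbers stand for stronger inhibition and higher numbers for weaker inhibition), compound 3 gives > 5000 nM, which is a limit of the assay rather than a number. Compound 1 `NS(=O)(=O)c1ccc(COc2ccc(CNC(=O)[C@@H]3CCC(=O)N3Cc3ccc(F)cc3)cc2)cc1` extends the core through a benzyl ether to a sulfonamide-bearing ring; in this assay compound 1 gives > 5000 nM, again a limit. Compound 2 `CC1(C)OB(c2ccc(COc3ccc(CNC(=O)[C@H]4CCC(=O)N4Cc4ccccc4)cc3)cc2)OC1(C)C` carries the same extension but ends in a boronate ester; in this assay compound 2 gives 180 nM. Going by the values given here, compound 2 thus holds the only numerical value in the set, the remaining two results sitting at a limit (the limit of > 5000 nM in this assay, at which 2 of the 3 values shown sit).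

Compound 4 `O=C(O)c1ccc(COc2ccc(CNC(=O)[C@H]3CCC(=O)N3Cc3ccccc3)cc2)cc1` keeps everything of compound 2 except the terminal group: a group of 3 heavy atoms (1 carbon, 2 oxygen; no ring) in place of a group of 9 heavy atoms (6 carbon, 1 boron, 2 oxygen; one five-membered non-aromatic ring with 3 hetero atoms), on an aromatic carbon. Among the compounds with values here, no measured pair differs in one place, so no measured step guides the change. The only numerical result rests on the boronate ester of compound 2, and a loss beyond the usual scatter is expected for compound 4. Compound 4 is expected near 1500 nM, estimated to fall between 300 nM and 8000 nM. That estimate corresponds to an expected step of an 8.3-fold higher number from compound 2 to compound 4 (0.92 log units; beyond the scatter).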

Compound 4, half-maximal inhibitory concentration: > 5000 nM
Compound 4: a limit, no number; the forecaster's own chance of this, stated with the estimate: 35%; at least 3.3-fold (0.52 log units) between middle value and limit.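

In this assay compound 4 gives > 5000 nM, which is a limit of the assay and not a number. Going by these compounds alone, exchanging the boronate ester for carboxy on this aromatic carbon, para to a large group, gives an at least 27-fold higher number from compound 2 to compound 4 (1.44 log units; beyond the scatter), the first one-place comparison in the set and the first direct sign that the measurable inhibition of compound 2 depends on what ends the distal ring, since the benzyl ether extension alone does not carry it in compound 4. The size of this step can be read only as a bound, and the set still contains a single number: the limit of > 5000 nM in this assay, at which 3 of the 4 values shown sit.

The compounds shown do not separate a loss tied to the departure of the boronate ester from one tied to the arrival of carboxy, a question that a free boronic acid, a methyl ester or a primary carboxamide on the same carbon would bear on. They also leave open whether any terminal group other than the boronate ester can hold a numerical value on this read-out, and how far the shared core contributes to that value.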